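A few compounds are considered here, and "the series" means these few. Any claim that something is new, unique, unknown or untested is made for them only; others in the source may bear on it.

Compound 1 `Nc1ncnc2c1c(Oc1cccc(Cl)c1)nn2CC1CCNCC1`: > 1 h
Compound 2 `Nc1ncnc2c1c(Oc1cccc(Cl)c1)nn2CC1(C(F)(F)F)CC1`: 0.183 h

Among the measured compounds shown here, in an ADME assay on microsomes from liver (Rattus norvegicus) for metabolic stability, read by LC-MS, tested at 1 uM (on this read-out higher numbers stand for a longer-lived compound and lower numbers for a shorter-lived compound), compound 2 gives 0.183 h, the only actual number so far. For compound 1, > 1 h is a limit of the assay and not a number.

Compound 3 `Nc1ncnc2c1c(Oc1cccc(Cl)c1)nn2CC1CCNC1` has not yet been measured. Its difference from compound 2 is pyrrolidin-3-yl in place of 1-(trifluoromethyl)cyclopropyl on a saturated chain carbon bound to an aromatic nitrogen. For the measured compounds named here, one measured step bears on this: an at least 5.4-fold lower number from compound 1 to compound 2 (0.73 log units; beyond the scatter), where 1-(trifluoromethyl)cyclopropyl took the place of piperidin-4-yl. Compound 3 removes that same group and puts pyrrolidin-3-yl on the saturated chain carbon, so the change resembles that step run backwards. A rise of comparable size in this assay, beyond the scatter, is therefore expected, though this rests on a single pair whose size is only bounded. The expected change is a 4.9-fold higher number from compound 2 to compound 3 (0.69 log units; beyond the scatter). For compound 3 the estimated half-life is 0.9 h, with an expected range of 0.4 h to 2 h.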

Compound 3, half-life: > 1 h
Compound 3 was reported as a limit (the forecaster's own chance of this, stated with the estimate: 50%); middle value at least 1.1-fold (0.04 log units) away from the limit.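

In this assay, pyrrolidin-3-yl in place of 1-(trifluoromethyl)cyclopropyl on a saturated chain carbon bound to an aromatic nitrogen gives an at least 5.4-fold higher number from compound 2 to compound 3 (0.73 log units; beyond the scatter). A second saturated ring holding a nitrogen, this one five-membered, thus also stands clear of compound 2 at this position, so the gap first seen with compound 1 does not depend on piperidin-4-yl alone. Compound 3 gives > 1 h, which is a limit of the assay and not a number.

The step from compound 1 to compound 3 cannot be read, because both values are limits: the limit of > 1 h in this assay, at which 2 of the 3 values shown sit. Also open is whether the ring nitrogen or the loss of trifluoromethyl accounts for the change, and the compounds shown do not tell how plain cyclopropyl or an open-chain amine would stand in this place.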